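Methylating the amine of compound 2

The compounds below may be only part of what the source reports. "The series", "measured", "known", "first", "only" and "open" are said of these compounds alone.

Measured so far:
- compound 1 (`CC[C@H](NC)C(=O)N[C@@H]1C(=O)N2[C@@H](CC[C@@H]1CCNC(=O)c1ccccc1)CC[C@H]2C(=O)NC(c1ccccc1)c1ccccc1`) gives > 100000 nM (a limit)
- compound 2 (`CCNCC[C@H]1CC[C@H]2CC[C@@H](C(=O)NC(c3ccccc3)c3ccccc3)N2C(=O)[C@H]1NC(=O)[C@@H](N)CC`) gives > 100000 nM (a limit)

Both readings come from a functional assay on PC-3 cells (Homo sapiens) for cytotoxicity, read by MTT assay, with a stated time of 96 h; a lower number here means a stronger inhibitor, a higher number a weaker inhibitor. Compound 2 gives > 100000 nM, which is a limit of the assay and not a number. Among the compounds with values here, the series so far offers only (the limit of > 100000 nM in this assay, at which 2 of the 2 values shown sit). Within the data shown here, no measured step exists, so the data give no size for any structural change.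

Compound 3 (`CCNCC[C@H]1CC[C@H]2CC[C@@H](C(=O)NC(c3ccccc3)c3ccccc3)N2C(=O)[C@H]1NC(=O)[C@H](CC)NC`) is still to be measured. It differs from compound 2 in one place, with methyl in place of hydrogen on an amine nitrogen. This turns amino into methylamino, or 1-aminopropyl into 1-(methylamino)propyl.

Compound 2 provides no number to start from, so in this assay any change could only appear as a lower reading. A modest move towards stronger inhibition is expected, with a substantial chance that the reading remains a limit. The expected step is an at least 1.6-fold lower number from compound 2 to compound 3 (0.22 log units; that floor lies within the scatter). The estimate for compound 3 is 60000 nM, with an expected range of 15000 nM to 100000 nM.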

Compound 3, half-maximal inhibitory concentration: > 100000 nM
Compound 3 ended at the assay's limit; the forecaster's own chance of this, stated with the estimate: 55%; at least 1.6-fold (0.22 log units) between middle value and limit.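

In this assay compound 3 gives > 100000 nM, a limit and not a number. No step from compound 1 or compound 2 to compound 3 can be read: the limit of > 100000 nM in this assay, at which 3 of the 3 values shown sit.

The compounds shown leave open whether methyl in place of hydrogen on an amine nitrogen changes the reading at all, and what any of their true values are.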